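A few compounds are considered here, and "the series" means these few. Any claim that something is new, unique, unknown or untested is made for them only; others in the source may bear on it.

In an ADME assay on Vero cells (Chlorocebus sabaeus) for cytotoxicity, read by MTT assay, with a stated time of 72 h (a higher number here means that more compound is tolerated, a lower number that less compound is tolerated), compound 1 `CC(C)c1ccc(C(Nc2ccc(C3(C)NC(=O)c4ccccc4N3)cc2)c2nnnn2C2CCCCC2)cc1` gives > 400000 nM, which is a limit of the assay and not a number. Compound 2 `COc1cccc(-c2cc(-c3ccc(C4NC(=O)c5ccccc5N4)cc3)nc(N)n2)c1OC` also gives only a limit, > 400000 nM. For compound 3 `CCCCNC(c1ccc(C2NC(=O)c3ccccc3N2)cc1)c1nnnn1C(C)(C)C` the entry reads "not determined" (no result reported), so this compound adds no measurement. Among the measured compounds shown here, the series so far therefore offers (the limit of > 400000 nM in this assay, at which 2 of the 3 values shown sit), and compound 1 cannot be ranked more closely than that.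

The next compound is compound 4 `CC(C)c1ccc(C(Nc2ccc(C3(C)NC(=O)c4ccccc4N3)cc2)c2nnnn2C(C)(C)C)cc1`, which differs from compound 1 in one place: tert-butyl in place of cyclohexyl on an aromatic nitrogen. Tert-butyl takes the place of cyclohexyl on an aromatic nitrogen of the tetrazole, and the rest of the structure stays the same. For the measured compounds named here, compound 3 carries the same 1-(tert-butyl)-1H-tetrazol-5-yl group but has no result, and no two measured compounds differ in a single place, so the size of this change has not been measured directly.

The expectation rests on compound 1, with its limit of > 400000 nM. No step beyond the usual scatter is expected, and the estimated step of a number no higher from compound 1 to compound 4 (the limit leaves the size open) reflects that. A limit rather than a number is the likeliest report. For compound 4 the estimated value is 400000 nM, with an expected range of 200000 nM to 800000 nM.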

Compound 4, half-maximal cytotoxic concentration: > 400000 nM
Compound 4 gave a limit, no number (the forecaster's own chance of this, stated with the estimate: 75%); the middle value sits exactly at the limit.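

No step can be read between compound 1 and compound 4 in this assay for tert-butyl in place of cyclohexyl on an aromatic nitrogen, as both give only a limit: the limit of > 400000 nM in this assay, at which 3 of the 4 values shown sit.

The compounds shown leave open where any of them would fall as a number in this assay, and whether this change moves that number at all.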